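From 4-methylbenzyl to 2,4-dichlorobenzyl on a shared core

This account rests on a few compounds, and the source may have more. Where it says the series, first, only, none or still open, it means among the compounds named here.

Of the compounds shown here, three with a shared core have been tested in a functional assay on A549 cells (Homo sapiens) for cytotoxicity, read by MTT assay, with a stated time of 72 h; a lower number here means a stronger inhibitor, a higher number a weaker inhibitor: compound 1 `CN(C)Cc1ccc2nc(NC(=O)N/N=C/c3cn(Cc4ccc(C(C)(C)C)cc4)c4ccccc34)sc2c1` gives 1850 nM, compound 2 `CN(C)Cc1ccc2nc(NC(=O)N/N=C/c3cn(Cc4ccc(Cl)cc4)c4ccccc34)sc2c1` gives 840 nM and compound 3 `Cc1ccc(Cn2cc(/C=N/NC(=O)Nc3nc4ccc(CN(C)C)cc4s3)c3ccccc32)cc1` gives 1600 nM. Compound 3 cannot be told apart from either of the others, as the data show a 1.2-fold lower number from compound 1 to compound 3 (0.06 log units; within the scatter) and a 1.9-fold higher number from compound 2 to compound 3 (0.28 log units; within the scatter).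

Compound 4 `CN(C)Cc1ccc2nc(NC(=O)N/N=C/c3cn(Cc4ccc(Cl)cc4Cl)c4ccccc34)sc2c1` has not yet been measured. Its difference is 2,4-dichlorophenyl in place of 4-methylphenyl on a saturated chain carbon bound to an aromatic nitrogen: 2,4-dichlorophenyl stands in place of 4-methylphenyl on a saturated chain carbon bound to an aromatic nitrogen.

Going by the values given here, the only step beyond the scatter is a 2.2-fold lower number from compound 1 to compound 2 (0.34 log units; beyond the scatter), a modest one that brings in chloro. Compound 4 also carries chlorine, so the value of compound 2 at 840 nM is the best guide. Among the compounds with values here, no tested compound carries the 2,4-dichlorophenyl group, so this guide is loose. A modest move to a lower number in this assay is therefore expected. The expected size is a 2.0-fold lower number from compound 3 to compound 4 (0.30 log units; within the scatter). For compound 4 the estimated value is 800 nM, within an expected range of 350 nM to 1800 nM.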

Compound 4, half-maximal inhibitory concentration: 2000 nM
The estimate for compound 4 lay 2.5-fold (0.40 log units) below the measured number; measured number above the stated range.
By their numbers in this assay, from the lowest: compounds 2, 3, 1 and 4 (each within the scatter of the next, the first and the last beyond it).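

A second chlorine on the benzyl group does not keep the lower number that the single chlorine gave: chloro in place of hydrogen on an aromatic carbon gives a 2.4-fold higher number from compound 2 to compound 4 (0.38 log units; beyond the scatter), a modest step beyond the scatter. So chlorine on this benzyl group does not by itself go with a lower number, and the 2,4-dichlorobenzyl group cannot be told apart from 4-methylbenzyl, with a 1.3-fold higher number from compound 3 to compound 4 (0.10 log units; within the scatter), or from 4-tert-butylbenzyl, with a 1.1-fold higher number from compound 1 to compound 4 (0.03 log units; within the scatter). No measurement here explains why the second chlorine has this result.

On these data alone, it remains open whether 2-chlorobenzyl or 4-fluorobenzyl would give a number like that of compound 2 or like those of the other three. As far as these compounds go, how these steps would read with a morpholine in place of the dimethylamino group on the shared core also remains open.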